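Notes on chain extension across two cores

The source may report more compounds than this note shows. Statements on the series, on what has been measured and on what is new or still open speak of the compounds shown alone.

Measured compounds:
compound 1, `CCCCCCOc1ccc(-c2c(C)[nH]c(=O)n2C)cc1`, 7300 nM
compound 2, `CCCCCCCCOc1ccc(-c2c(C)[nH]c(=O)n2C)cc1`, 4000 nM
compound 3, `CCCCCCCCc1ccc(-c2c(C)[nH]c(=O)n2C2CCCCC2)cc1`, 10300 nM

All three were run in a functional assay on brain (Rattus norvegicus, strain Wistar) for inhibition; a higher number here means a weaker inhibitor, a lower number a stronger inhibitor. From compound 1 to compound 2 the change is ethyl in place of hydrogen on a saturated chain carbon, six bonds along the chain from an oxygen on an aromatic ring, and it gave a 1.8-fold lower number from compound 1 to compound 2 (0.26 log units; within the scatter). Compound 3 stands on a different core; the difference between the two cores is not broken down here, and compound 3 shows the highest number of the three.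

Compound 4, `CCCCCCCCCCc1ccc(-c2c(C)[nH]c(=O)n2C2CCCCC2)cc1`, is not yet measured. It differs from compound 3 by ethyl in place of hydrogen on a saturated chain carbon, eight bonds along the chain from an aromatic carbon. This is the same kind of change as between compound 1 and compound 2, though the place differs: eight bonds along the chain from an aromatic carbon rather than six bonds along the chain from an oxygen on an aromatic ring. Among the measured compounds shown here, the only guide is a 1.8-fold lower number from compound 1 to compound 2 (0.26 log units; within the scatter), and the cores differ, so the expectation is loose. Compound 4 is expected near 6000 nM in this assay, between 2800 nM and 13000 nM. The expected step is a 1.7-fold lower number from compound 3 to compound 4 (0.23 log units; within the scatter).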

Compound 4, half-maximal inhibitory concentration: 27000 nM
For compound 4 the middle estimate is 4.5-fold (0.65 log units) below the measured one; the measured number lies above the stated range.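

In this assay, ethyl in place of hydrogen on the saturated chain gives a 2.6-fold higher number from compound 3 to compound 4 (0.42 log units; beyond the scatter), which makes compound 4 the weaker inhibitor of this pair. The same change therefore does not carry over unaltered from the core of compound 1 to the core of compound 3: the same change on two cores in this assay, a 1.8-fold lower number (0.26 log units; within the scatter) from compound 1 to compound 2 and a 2.6-fold higher number (0.42 log units; beyond the scatter) from compound 3 to compound 4, 4.8-fold (0.68 log units) apart, beyond the scatter of two such steps. With one pair on each core and a different place of change in each pair, this does not show whether the core or the place sets the gap, and it establishes no general trend with chain length.

Still open, on these data alone, is how a longer chain would read on either core. Also open, as far as these compounds go, is whether an amine or a carboxylic acid on the chain would change the picture in this assay.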